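The source may report more compounds than this note shows. Statements on the series, on what has been measured and on what is new or still open speak of the compounds shown alone.

Compound 1 `CC(C)[C@H](C(=O)NC(C)(C)C)c1ccc(Cl)cc1` and compound 2 `CC(C)[C@H](C(=O)Nc1cccnn1)c1ccc(Cl)cc1` differ only on the amide-type nitrogen. In a functional assay on CHO cells for agonist activity at Free fatty acid receptor 2 (Homo sapiens), read by cAMP accumulation (on this read-out lower numbers stand for stronger inhibition and higher numbers for weaker inhibition), compound 1 reaches only a limit, > 100000 nM. In this assay, among the measured compounds shown here, compound 2 gives 2300 nM, the single full number. The step of an at least 43-fold lower number from compound 1 to compound 2 (1.63 log units; beyond the scatter) is thus measured against the limit of > 100000 nM in this assay, at which 1 of the 2 values shown sits, rather than a number. Compound 3 `CC(C)[C@H](C(=O)Nc1ncc[nH]1)c1ccc(Cl)cc1` alters the same position: 1H-imidazol-2-yl in place of pyridazin-3-yl on an amide-type nitrogen. For the measured compounds named here, the step from compound 1 to compound 2 bears on it only in showing a heteroaryl group active where tert-butyl is not; no measured step compares two heteroaryl groups. A step within the scatter is expected, a 1.7-fold higher number from compound 2 to compound 3 (0.24 log units; within the scatter). Compound 3 is estimated at 4000 nM, range 1000 nM to 20000 nM.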

Compound 3, half-maximal inhibitory concentration: 20000 nM
Beside the measured number, compound 3's estimate is 5.0-fold (0.70 log units) below it, and the stated range covers the measured number.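

In this assay, a direct comparison of two heteroaryl groups on the amide-type nitrogen gives an 8.7-fold higher number from compound 2 to compound 3 (0.94 log units; beyond the scatter), so 1H-imidazol-2-yl and pyridazin-3-yl are not interchangeable at this position. 1H-imidazol-2-yl still gives an at least 5.0-fold lower number from compound 1 to compound 3 (0.69 log units; beyond the scatter), which makes it a second heteroaryl group to improve on tert-butyl, though this step is measured against a limit of the assay: the limit of > 100000 nM in this assay, at which 1 of the 3 values shown sits.

This change alters ring size and the donor and acceptor counts together, and the compounds shown do not separate these. As far as these compounds go, how a pyridin-2-yl or a thiazol-2-yl group would fare on this nitrogen stays open.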